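Aminoisobutyryl to pyrazinoyl on the amide of compound 1

The source may hold more compounds than are shown below. What is called first, only, known or untested is meant among the compounds shown, and "the series" means these compounds.

Among the compounds with values here, compound 1 `COc1ccc(Cn2c(CCc3c[nH]c4ccccc34)nnc2[C@H](NC(=O)C(C)(C)N)c2c[nH]c3ccccc23)c(OC)c1` sits in the middle of the three numbers so far: in an in vitro assay on LLC-PK1 cells for displacement of a labelled ligand from growth hormone secretagogue receptor type 1 (Homo sapiens) (a higher number here means a weaker inhibitor, a lower number a stronger inhibitor), compound 1 gives 108 nM, compound 2 `COc1ccc(Cn2c(CCc3ccccc3)nnc2[C@H](NC(=O)C(C)(C)N)c2c[nH]c3ccccc23)c(OC)c1` gives 60 nM and compound 3 `O=C(N[C@H](c1c[nH]c2ccccc12)c1nnc(CCc2c[nH]c3ccccc23)n1-c1ccccc1)c1ccccn1` gives 160 nM. Within the data shown here, the single one-place step measured, a 1.8-fold lower number from compound 1 to compound 2 (0.26 log units; within the scatter), concerns the chain end and not the amide. Compound 4 `COc1ccc(Cn2c(CCc3c[nH]c4ccccc34)nnc2[C@H](NC(=O)c2cnccn2)c2c[nH]c3ccccc23)c(OC)c1` carries pyrazin-2-yl in place of 1-amino-1-methylethyl on a carbonyl carbon. Among the measured compounds shown here, no measured step changes the amide alone; compound 3 has an aromatic heterocycle on its carbonyl carbon as well, but it also differs from compound 1 at the triazole nitrogen, so its two values only show that compound 1 and compound 3 lie within the scatter of each other. With nothing bearing directly on the change, the expectation for compound 4 in this assay is a step of about a 1.4-fold higher number from compound 1 to compound 4 (0.14 log units; within the scatter), which is no change beyond the scatter. Compound 4 is therefore estimated at 150 nM, with a range from 50 nM to 450 nM.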

Compound 4, half-maximal inhibitory concentration: 18.5 nM
Compound 4: middle estimate off by 8.1-fold (0.91 log units), on the high side, and the stated range ends above it.
By their numbers in this assay, from the lowest: compound 4; then compounds 2, 1 and 3 (each within the scatter of the next, the first and the last beyond it).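

Within the data shown here, the amide position is the first place where a one-place change moves the number beyond the scatter: in this assay, pyrazin-2-yl in place of 1-amino-1-methylethyl on the carbonyl carbon gives a 5.8-fold lower number from compound 1 to compound 4 (0.77 log units; beyond the scatter). The 1-amino-1-methylethyl group is therefore not needed for a value at this level on the core of compound 1, since the pyrazin-2-yl group that enters has no hydrogen-bond donor, whereas the group that leaves has one. Nothing measured on hand ties this step to any particular feature of either group.

Going by these compounds, it remains open whether the step depends on the ring nitrogens of the pyrazin-2-yl group, which a cyclohexyl or pyrimidin-2-yl group on the same carbonyl carbon would test. Also open, on these data alone, is whether the step carries over to the phenyl chain end of compound 2.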